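Methyl to trifluoromethyl on a compound at the assay limit

This account rests on a few compounds, and the source may have more. Where it says the series, first, only, none or still open, it means among the compounds named here.

Compound 1, `C/C(=C\c1cc(-c2ccccc2)co1)C(N)=O`: 42400 nM
Compound 2, `C/C(=C\c1cc(-c2ccc(F)nc2)co1)C(N)=O`: 30000 nM
Compound 3, `C/C(=C\c1cc(-c2ccc(C)cc2)cs1)C(N)=O`: > 50000 nM (a limit, no number)

All three compounds were tested in a functional assay on HO8910 cells (Homo sapiens) for cytotoxicity, read by CCK-8 assay, with a stated time of 24 h; a lower number here means a stronger inhibitor, a higher number a weaker inhibitor. Compound 1 gives 42400 nM and compound 2 gives 30000 nM; these two values lie within the usual scatter of each other, so no order between them can be read. For compound 3 the result is a limit of the assay rather than a number, and compound 3 therefore stands at the limit of > 50000 nM in this assay, at which 1 of the 3 values shown sits.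

Compound 4, `C/C(=C\c1cc(-c2ccc(C(F)(F)F)cc2)cs1)C(N)=O`, differs from compound 3 in one place: trifluoromethyl in place of methyl on an aromatic carbon. Going by the values given here, no pair of measured compounds shows a change of this kind, so the data give no measured step from which its size could be read. Since compound 3 already sits at the limit, the expectation is that compound 4 will also show weak inhibition, with the step from compound 3 to compound 4 expected to be a number no higher from compound 3 to compound 4 (the limit leaves the size open), none beyond the scatter. Compound 4 is estimated at 50000 nM, in the range from 15000 nM to 160000 nM, with a real chance that this assay again reports only a limit.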

Compound 4, half-maximal inhibitory concentration: > 50000 nM
Compound 4 was reported as a limit; the forecaster's own chance of this, stated with the estimate: 60%; the middle value sits exactly at the limit.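

In this assay compound 4 gives > 50000 nM, which is a limit of the assay and not a number. Compound 3 also stands at a limit, so no step can be read between compound 3 and compound 4: the limit of > 50000 nM in this assay, at which 2 of the 4 values shown sit.

The compounds shown leave open how strongly either compound acts, and whether trifluoromethyl in place of methyl changes that at all.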